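The source may hold more compounds than are shown below. What is called first, only, known or untested is meant among the compounds shown, and "the series" means these compounds.

Series notes. Compound 1 `COc1cc(-c2nnc(SCC(=O)c3ccc(Cl)cc3)n2N)cc(OC)c1OC`, compound 2 `COc1cc(-c2nnc(SCC(=O)c3ccc(C)cc3)n2N)cc(OC)c1OC` and compound 3 `COc1cc(-c2nnc(SCC(=O)NCc3ccc(Cl)cc3)n2N)cc(OC)c1OC` have been measured; compound 4 `COc1cc(-c2nnc(SCC(=O)NCc3ccc(C)cc3)n2N)cc(OC)c1OC` has not. In a functional assay on HeLa cells (Homo sapiens) for antiproliferative activity, read by MTT assay, with a stated time of 48 h (on this read-out higher numbers stand for weaker inhibition and lower numbers for stronger inhibition), compound 1 gives 13100 nM. In this assay compound 2 gives 2940 nM. The step of a 4.5-fold lower number from compound 1 to compound 2 (0.65 log units; beyond the scatter) goes with the change (methyl in place of chloro on an aromatic carbon). For compound 3 the value > 100000 nM is a limit of this assay and not a number, as marked by the limit of > 100000 nM in this assay, at which 1 of the 3 values shown sits. The core of compound 3 differs from the core of compound 1 by (4-chlorobenzyl)amino in place of 4-chlorophenyl on a carbonyl carbon; the step is an at least 7.6-fold higher number from compound 1 to compound 3 (0.88 log units; beyond the scatter), and against compound 2 it is an at least 34-fold higher number from compound 2 to compound 3 (1.53 log units; beyond the scatter). Compound 4 differs from compound 3 by methyl in place of chloro on an aromatic carbon, the same change as from compound 1 to compound 2, at a place described in the same words. A step of an at least 1.6-fold lower number from compound 3 to compound 4 (0.22 log units; that floor lies within the scatter) is expected, set beside the measured 4.5-fold lower number from compound 1 to compound 2 (0.65 log units; beyond the scatter), and rests on compound 1 and compound 2 alone. Compound 3 itself gives only the limit > 100000 nM, so the starting point is uncertain and a limit may again be reported. Compound 4 is estimated at 60000 nM, between 15000 nM and 300000 nM.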

Compound 4, half-maximal inhibitory concentration: > 100000 nM
Compound 4 gave a limit, no number; the forecaster's own chance of this, stated with the estimate: 40%; middle value at least 1.6-fold (0.22 log units) from the limit.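

In this assay compound 4 gives > 100000 nM, which is a limit of the assay and not a number. Compound 3 also stands at a limit, so the step between compound 3 and compound 4 cannot be read, and the methyl-for-chloro change, seen as a 4.5-fold lower number from compound 1 to compound 2 (0.65 log units; beyond the scatter), is neither confirmed nor contradicted on the core of compound 3: the limit of > 100000 nM in this assay, at which 2 of the 4 values shown sit. What can be read is the larger change on the carbonyl carbon, with an at least 34-fold higher number from compound 2 to compound 4 (1.53 log units; beyond the scatter) and an at least 7.6-fold higher number from compound 1 to compound 4 (0.88 log units; beyond the scatter), so on this read-out (4-methylbenzyl)amino goes with weaker inhibition than either aryl group.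

The compounds shown leave open whether the core of compound 3 can give a number within the range of the assay at all, for instance with a methoxy group in place of the methyl or a longer chain in place of the benzyl. They also leave open how the core of compound 1 responds at that same place to groups other than chloro and methyl, such as an amine or a carboxylic acid.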